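From an Inactive Fluoro Analogue to a Methylcarbamoyl Variant

This account rests on a few compounds, and the source may have more. Where it says the series, first, only, none or still open, it means among the compounds named here.

Compound 1 `CC[C@@H]1C(=O)N(C)c2cnc(-n3ccc4cc(F)ccc43)nc2N1C1CCCC1` was tested in a functional assay on HeLa cells (Homo sapiens) for antiproliferative activity, read by CCK-8 assay, with a stated time of 72 h (a lower number here means a stronger inhibitor of growth, a higher number a weaker inhibitor of growth), and compound 1 was recorded as "not active" (no number reported), so no single number places it on the scale. Two related compounds do give numbers. Compound 2 `CCC1C(=O)N(C)c2cnc(-n3ccc4cc(C(=O)NCC(C)C)ccc43)nc2N1c1ccn(C)n1` carries a branched amide on its fused two-ring system, and in this assay compound 2 gives 4970 nM. Compound 3 `CCC1C(=O)N(C)c2cnc(Nc3ccc(S(N)(=O)=O)cc3)nc2N1c1ccn(C)n1` differs more widely and bears a sulfonamide instead, and in this assay compound 3 gives 12600 nM. Among the compounds with values here, neither shares only one point of difference with compound 1, so their values show only that amide-bearing and sulfonamide-bearing members reach modest growth inhibition.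

Compound 4 `CC[C@@H]1C(=O)N(C)c2cnc(-n3ccc4cc(C(=O)NC)ccc43)nc2N1C1CCCC1` keeps the core and the cyclopentyl of compound 1 and differs in one place: methylcarbamoyl in place of fluoro on an aromatic carbon. Within the data shown here, no measured step matches this change. Since compound 1 gave no number, the direction from compound 1 cannot be read, but the amide-bearing compound 2 with 4970 nM suggests a compound in that range rather than a silent one. Compound 4 is therefore expected to show measurable but modest inhibition, with an estimated value of 6000 nM and a range from 1500 nM to 25000 nM.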

Compound 4, concentration for 50% growth inhibition: 768 nM
Compound 4: the middle estimate sits 7.8-fold (0.89 log units) above what was measured, outside the stated range (below it).
By their numbers in this assay, from the lowest: compound 4; then compound 2; then compound 3.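

In this assay, within the data shown here, compound 1 stands as "not active" (no number reported) and compound 4 gives 768 nM, so no step between the two can be read. Nothing measured here accounts for the value of compound 4. The compounds shown leave open how other groups at that aromatic carbon would compare with methylcarbamoyl on the same scaffold.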